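The compounds below may be only part of what the source reports. "The series", "measured", "known", "first", "only" and "open" are said of these compounds alone.

Compound 2 `CCCn1c(=O)[nH]c2nc(-c3ccc(S(=O)(=O)N4CCN(c5cccc(Cl)c5)CC4)cc3)[nH]c2c1=O` is tested in an assay on CHO cells for displacement of a labelled ligand from adenosine receptor A3 (Homo sapiens), read by scintillation counting, with a stated time of 45 min, in the presence of a further agent that is not named here (on this read-out higher numbers stand for weaker inhibition and lower numbers for stronger inhibition), where compound 2 gives 53.5 nM. Compound 1 `CCCn1c(=O)[nH]c2nc(-c3ccc(S(=O)(=O)N4CCN(c5ccc(Cl)cc5F)CC4)cc3)[nH]c2c1=O` reaches only a limit in this assay, > 1000 nM. Compound 3 `CCCn1c(=O)c2[nH]c(-c3ccc(S(=O)(=O)N4CCN(c5ccc(Cl)cc5)CC4)cc3)nc2n(C)c1=O` likewise reaches only a limit, > 1000 nM. Among the measured compounds shown here, compound 2 therefore holds the only number among the three, the other two resting at the limit of > 1000 nM in this assay, at which 2 of the 3 values shown sit. Compound 4 `CCCn1c(=O)[nH]c2nc(-c3ccc(S(=O)(=O)N4CCN(C(C)c5ccccc5)CC4)cc3)[nH]c2c1=O` has not been measured; it differs from compound 2 by 1-phenylethyl in place of 3-chlorophenyl on an amine nitrogen in a ring. For the measured compounds named here, the one measured step that touches this ring nitrogen is an at least 18-fold lower number from compound 1 to compound 2 (1.27 log units; beyond the scatter), showing that the group there can shift the read-out strongly. In this assay the expected step is a 3.0-fold higher number from compound 2 to compound 4 (0.48 log units; beyond the scatter), toward a weaker number. Compound 4 is accordingly estimated at 160 nM, within 40 nM to 650 nM.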

Compound 4, inhibition constant: > 1000 nM
Compound 4: only a limit was reported (the forecaster's own chance of this, stated with the estimate: 20%); middle value at least 6.2-fold (0.79 log units) away from the limit.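

Putting 1-phenylethyl in place of 3-chlorophenyl on the amine nitrogen in the ring gives an at least 18-fold higher number from compound 2 to compound 4 (1.27 log units; beyond the scatter). The result for compound 4 is a limit, not a number. A second group at this nitrogen thus joins 4-chloro-2-fluorophenyl in giving no measured number, and compound 2 stands alone among the compounds at this position: the limit of > 1000 nM in this assay, at which 3 of the 4 values shown sit.

The step between the two other groups at this nitrogen cannot be read, as both results are limits. From the compounds shown here alone, it remains open whether a 3-chlorobenzyl or a plain benzyl group here would give a measured number.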